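Swapping dimethylamino for hydroxybenzylamino in the diphenylamine ether series

The source may hold more compounds than are shown below. What is called first, only, known or untested is meant among the compounds shown, and "the series" means these compounds.

Compound 2 `COc1cc(Oc2cccc(Nc3ccccc3)c2)cc(OC)c1CN(C)C` carries the highest number of the two compounds measured; in a functional assay on HCT-116 cells (Homo sapiens) for inhibition, read by MTT assay, with a stated time of 72 h (a higher number here means a weaker inhibitor, a lower number a stronger inhibitor), compound 2 gives 12900 nM. Compound 1 `COc1cc(Oc2cccc(Nc3ccccc3)c2)cc(OC)c1CNCc1ccc(Cl)cc1` gives 3310 nM in this assay. Compound 3 `COc1cc(Oc2cccc(Nc3ccccc3)c2)cc(OC)c1CNCc1ccc(O)cc1` differs from compound 2 by (4-hydroxybenzyl)amino in place of dimethylamino on a saturated chain carbon bound to an aromatic carbon. Within the data shown here, the one relevant step runs the other way: a 3.9-fold higher number from compound 1 to compound 2 (0.59 log units; beyond the scatter). Reversing that change, with a hydroxy group in place of the chloro, is expected to lower the number in this assay by a comparable margin, a 3.2-fold lower number from compound 2 to compound 3 (0.51 log units; beyond the scatter). Compound 3 is therefore estimated at 4000 nM, with a range from 1500 nM to 12000 nM.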

Compound 3, half-maximal inhibitory concentration: 3360 nM
The estimate for compound 3 lay 1.2-fold (0.08 log units) above the measured number; measured number inside the range.
By their numbers in this assay, from the lowest: compounds 1 and 3 (each within the scatter of the next); then compound 2.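

In this assay, a second benzylamino compound also gives a lower number than the dimethylamino compound (a 3.8-fold lower number from compound 2 to compound 3 (0.58 log units; beyond the scatter)), so this step is not tied to the chloro group. With hydroxy in place of chloro on an aromatic carbon, the two benzylamino compounds lie within the scatter of each other (a 1.0-fold higher number from compound 1 to compound 3 (0.01 log units; within the scatter)), and the assay does not separate these two groups. From the compounds shown here alone, whether an amine or a carboxylic acid on that aromatic carbon would read the same remains open. Nothing given here explains why the hydroxy and chloro compounds read alike.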